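Working notes: estimating compound 4 before its measurement

A few compounds are considered here, and "the series" means these few. Any claim that something is new, unique, unknown or untested is made for them only; others in the source may bear on it.

Measured so far:
compound 1 `O=C1c2ccccc2N(COCc2ccccc2)S(=O)(=O)N1COCc1ccccc1` — 27700 nM
compound 2 `O=C1c2ccccc2N(Cc2ccccc2Cl)S(=O)(=O)N1Cc1ccccc1Cl` — 40400 nM
compound 3 `O=C1c2ccccc2N(Cc2ccccc2)S(=O)(=O)N1Cc1ccc(Cl)cc1` — 27800 nM

All three numbers come from a functional assay on CCRF-CEM cells (Homo sapiens) for inhibition; on this read-out higher numbers stand for lower toxicity in this test and lower numbers for higher toxicity in this test. Compound 2 stands at the top of the three numbers on paper, but its distance to compound 3 and its distance to compound 1 both lie within the usual scatter, so the three compounds are not told apart by this assay. Going by the values given here, no pair of them differs in only one place, so no single step can be read from the measured set.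

Compound 4 `O=C1c2ccccc2N(Cc2ccccc2Cl)S(=O)(=O)N1COCc1ccccc1` is the next candidate. Relative to compound 2 the change is benzyloxy in place of 2-chlorophenyl on a saturated chain carbon bound to an amide-type nitrogen in a ring. Compound 4 thus carries one substituent of compound 2 and one substituent of compound 1, and those two parents sit within the scatter of each other in this assay. No step beyond the scatter is expected from compound 2 to compound 4; the expected step is a 1.3-fold lower number from compound 2 to compound 4 (0.10 log units; within the scatter). Compound 4 is estimated at 32000 nM, with a range from 15000 nM to 70000 nM.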

Compound 4, half-maximal cytotoxic concentration: 22200 nM
Beside the measured number, compound 4's estimate is 1.4-fold (0.16 log units) above it, and the stated range covers the measured number.
By their numbers in this assay, from the lowest: compounds 4, 1, 3 and 2 (each within the scatter of the next).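

Going by these compounds alone, compound 4 gives the first comparisons that differ in one place. In this assay, benzyloxy in place of 2-chlorophenyl on a saturated chain carbon bound to an amide-type nitrogen in a ring gives one step (a 1.8-fold lower number from compound 2 to compound 4 (0.26 log units; within the scatter)), and 2-chlorophenyl in place of benzyloxy on a saturated chain carbon bound to a sulfonamide nitrogen in a ring gives the other (a 1.2-fold lower number from compound 1 to compound 4 (0.10 log units; within the scatter)). Both steps lie within the scatter, so the assay does not separate these two groups at either place, and no measured evidence is available to bear on this result.

As far as these compounds go, whether an amine or a carboxylic acid at either place would give a step beyond the scatter stays open. The same holds for a longer chain carrying the phenyl ring.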